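Tetrazole for Thiadiazole on the Thioether Sulfur

The source may report more compounds than this note shows. Statements on the series, on what has been measured and on what is new or still open speak of the compounds shown alone.

Compound 2 `Cc1nnc(SCC(=O)N/N=c2/scc(-c3ccc(F)cc3)n2-c2ccccc2)s1` gives 383 ug/mL in an ADME assay on NIH3T3 cells (Mus musculus) for cytotoxicity, read by MTT assay, with a stated time of 24 h; on this read-out lower numbers stand for stronger inhibition and higher numbers for weaker inhibition. Within the data shown here, its only neighbour with a number, compound 1 `Cc1nnc(SCC(=O)N/N=c2/scc(-c3ccccc3)n2-c2ccccc2)s1`, gives 197 ug/mL in this assay, and the step of a 1.9-fold higher number from compound 1 to compound 2 (0.29 log units; within the scatter) places the two within the scatter of each other, so compound 2 cannot be called the weaker of the pair. Compound 3 `Cn1nnnc1SCC(=O)N/N=c1/scc(-c2ccc(F)cc2)n1-c1ccccc1` differs from compound 2 by 1-methyl-1H-tetrazol-5-yl in place of 5-methyl-1,3,4-thiadiazol-2-yl on a sulfur. Among the measured compounds shown here, no measured step bears on this exchange: the single step recorded concerns a fluorine on an aromatic carbon, a different part of the molecule, and it was itself within the scatter. These data therefore give no reason to expect a change in either direction, and the expected step of a 1.1-fold lower number from compound 2 to compound 3 (0.04 log units; within the scatter) is set at nothing beyond the scatter. On that basis compound 3 is estimated at 350 ug/mL in this assay, with a range from 150 ug/mL to 800 ug/mL.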

Compound 3, half-maximal inhibitory concentration: 113 ug/mL
The estimate for compound 3 lay 3.1-fold (0.49 log units) above the measured number, outside the stated range (below it).
By their numbers in this assay, from the lowest: compounds 3, 1 and 2 (each within the scatter of the next, the first and the last beyond it).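

In this assay, 1-methyl-1H-tetrazol-5-yl in place of 5-methyl-1,3,4-thiadiazol-2-yl on a sulfur gives a 3.4-fold lower number from compound 2 to compound 3 (0.53 log units; beyond the scatter), a modest shift towards stronger inhibition. Among these compounds, this shows that the read-out responds to the group on this sulfur, whereas the only earlier step, a 1.9-fold higher number from compound 1 to compound 2 (0.29 log units; within the scatter), stayed within the scatter. The compounds shown offer no independent measurement that could explain the shift.

On these data alone, the exchange replaces the ring sulfur with nitrogen and also changes the number of hetero atoms, so this single step cannot separate those differences, and its effect without the fluoro group of compound 2 remains open. As far as these compounds go, it is also open how the number would respond to a phenyl ring, an amine or a carboxylic acid on this sulfur.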